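This account rests on a few compounds, and the source may have more. Where it says the series, first, only, none or still open, it means among the compounds named here.

Measured compounds in this series:
compound 1 `COc1cc(CSc2cc(Cl)c(-c3nnc(-c4ccc(Cl)cc4)s3)cc2S(=O)(=O)NC(=N)NO)cc(OC)c1OC` 8910 nM
compound 2 `COc1cc(CSc2cc(Cl)c(-c3nc(-c4ccccc4)no3)cc2S(=O)(=O)NC(=N)NO)cc(OC)c1OC` 3800 nM
compound 3 `COc1cc(CSc2cc(Cl)c(-c3nnc(-c4ccccc4)s3)cc2S(=O)(=O)NC(=N)NO)cc(OC)c1OC` 2040 nM

All three were run in a functional assay on NCI-H522 cells (Homo sapiens); on this read-out higher numbers stand for weaker inhibition of growth and lower numbers for stronger inhibition of growth. Compound 3 gives the lowest number of the three, although against compound 2 the gap is within the scatter; only compound 1 is separated from it by a step beyond the scatter, a 4.4-fold lower number from compound 1 to compound 3 (0.64 log units; beyond the scatter).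

Compound 4 `COc1cc(CSc2cc(Cl)c(-c3nc(-c4ccc(Cl)cc4)no3)cc2S(=O)(=O)NC(=N)NO)cc(OC)c1OC` is not yet measured. Its difference from compound 3 is 3-(4-chlorophenyl)-1,2,4-oxadiazol-5-yl in place of 5-phenyl-1,3,4-thiadiazol-2-yl on an aromatic carbon. Among the measured compounds shown here, two measured steps bear on it. The ring swap alone, from thiadiazole to oxadiazole, is seen in a 1.9-fold lower number from compound 2 to compound 3 (0.27 log units; within the scatter), which is within the scatter and carries little weight. The chloro on the pendant phenyl is seen in a 4.4-fold lower number from compound 1 to compound 3 (0.64 log units; beyond the scatter), a modest but clear loss of growth inhibition when chloro is present. Compound 1 already combines the chlorophenyl with a thiadiazole, and compound 4 keeps the chlorophenyl while taking the oxadiazole, so compound 4 is expected to sit near compound 1 or somewhat higher, with this assay read-out expected to rise from compound 3 by roughly a 5.9-fold higher number from compound 3 to compound 4 (0.77 log units; beyond the scatter).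

Compound 4 is therefore estimated at 12000 nM in this assay, with a range of 4000 nM to 36000 nM.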

Compound 4, concentration for 50% growth inhibition: 2140 nM
Beside the measured number, compound 4's estimate is 5.6-fold (0.75 log units) above it; measured number below the stated range.
By their numbers in this assay, from the lowest: compounds 3, 4 and 2 (each within the scatter of the next); then compound 1.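

In this assay, the chloro on the pendant phenyl does not carry a fixed penalty: with the 1,2,4-oxadiazole ring the step is a 1.8-fold lower number from compound 2 to compound 4 (0.25 log units; within the scatter), and the swap between the two groups at this position gives a 1.0-fold higher number from compound 3 to compound 4 (0.02 log units; within the scatter), so compound 3 and compound 4 cannot be told apart. The penalty appears only with the 5-(4-chlorophenyl)-1,3,4-thiadiazol-2-yl group of compound 1, and the ring swap between the two chlorophenyl groups is a clear step, a 4.2-fold lower number from compound 1 to compound 4 (0.62 log units; beyond the scatter), whereas without chloro the corresponding swap gives only a 1.9-fold lower number from compound 2 to compound 3 (0.27 log units; within the scatter). The effect of chloro on the pendant phenyl therefore depends on the five-membered ring that carries it, at least across these four compounds:  the same change on two cores in this assay, a 4.4-fold lower number (0.64 log units; beyond the scatter) from compound 1 to compound 3 and a 1.8-fold higher number (0.25 log units; within the scatter) from compound 4 to compound 2, 7.8-fold (0.89 log units) apart, beyond the scatter of two such steps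

The compounds shown leave open whether this dependence is particular to chloro or would also appear with a fluoro, a methoxy or an amine on the pendant phenyl of both ring types. They also leave open whether a group without the pendant phenyl, such as a simple methyl on the five-membered ring, would hold the numbers of compound 3 and compound 4.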